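Pyridine-substituent exchanges in a TRPV1 antagonist series

This account rests on a few compounds, and the source may have more. Where it says the series, first, only, none or still open, it means among the compounds named here.

Measured compounds:
compound 1, `CC(C(=O)NCc1ccc(C(C)(C)C)nc1N1CCC(Cc2ccccc2)CC1)c1ccc(NS(C)(=O)=O)c(F)c1` — 0.3 nM
compound 2, `CCOc1nc(C(C)(C)C)ccc1CNC(=O)C(C)c1ccc(NS(C)(=O)=O)c(F)c1` — 14.8 nM
compound 3, `CCOCCOc1nc(C(C)(C)C)ccc1CNC(=O)C(C)c1ccc(NS(C)(=O)=O)c(F)c1` — 23.9 nM

Readings come from an assay on cells for antagonist activity at transient receptor potential cation channel subfamily V member 1 (Homo sapiens), read by FLIPR and calcium flux, with a stated time of 6 min; a higher number here means a weaker inhibitor, a lower number a stronger inhibitor. Compound 3 gives the highest of the three numbers. Among the measured compounds shown here, its nearest neighbour is compound 2: the one step measured so far, a 1.6-fold higher number from compound 2 to compound 3 (0.21 log units; within the scatter), is within the scatter, so the two read as equal. Compound 1 is the furthest, with a far lower number, beyond the scatter.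

Compound 4, `CC(C(=O)NCc1ccc(C(C)(C)C)nc1C1CCCCC1)c1ccc(NS(C)(=O)=O)c(F)c1`, is the next compound. Against compound 3 the change is cyclohexyl in place of 2-ethoxyethoxy on an aromatic carbon. For the measured compounds named here, no measured step replaces an ether chain by a carbon ring at this place, so the single step on record, a 1.6-fold higher number from compound 2 to compound 3 (0.21 log units; within the scatter), bears on it only indirectly: lengthening the ether did not move the number. What does bear on it is the gap between compound 3 and compound 1, whose values show that a large, all-carbon substituent at this aromatic carbon sits far lower than either ether. Cyclohexyl resembles that group more than it resembles 2-ethoxyethoxy, so a sizeable drop is expected, though not the full distance to compound 1.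

Compound 4 is therefore estimated at 3 nM in this assay, in the range 0.7 nM to 12 nM. The expected step is an 8.0-fold lower number from compound 3 to compound 4 (0.90 log units; beyond the scatter).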

Compound 4, inhibition constant: 3.1 nM
Compound 4: middle estimate off by 1.0-fold (0.01 log units), on the low side; low and high end bracket the measured number.
By their numbers in this assay, from the lowest: compound 1; then compound 4; then compounds 2 and 3 (each within the scatter of the next).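

At the aromatic carbon next to the ring nitrogen, the exchange of 2-ethoxyethoxy for cyclohexyl moves the number in this assay beyond the scatter (a 7.7-fold lower number from compound 3 to compound 4 (0.89 log units; beyond the scatter)), whereas lengthening the ether did not (a 1.6-fold higher number from compound 2 to compound 3 (0.21 log units; within the scatter)). The exchange against the shorter ether is also beyond the scatter (a 4.8-fold lower number from compound 2 to compound 4 (0.68 log units; beyond the scatter)), so compound 4 lies below both ether compounds, which read as equal. Since 2-ethoxyethoxy and cyclohexyl each have 6 heavy atoms, heavy-atom count alone does not track the change between compound 3 and compound 4, and no measurement here explains the shift in this assay.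

The step from compound 3 to compound 4 removes 2 hydrogen-bond acceptors and adds a ring at once, so the compounds shown cannot separate those two changes; an open-chain n-hexyl group or a cyclohexyloxy group at this carbon would bear on that. Also open, as far as these compounds go, is what carries the number from compound 4 (3.1 nM) down to compound 1 (0.3 nM), and whether a phenyl or benzyl group at this carbon would fall between them.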